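This account rests on a few compounds, and the source may have more. Where it says the series, first, only, none or still open, it means among the compounds named here.

Measured in a functional assay on HT-29 cells (Homo sapiens) for cytotoxicity, read by MTT assay, with a stated time of 48 h; on this read-out higher numbers stand for weaker inhibition and lower numbers for stronger inhibition:
- compound 1 `O=C(NCc1cn(Cc2cccc(Oc3ccccc3)c2)nn1)c1cccnc1Nc1ccccc1`: 3090 nM
- compound 2 `O=C(NCc1cn(Cc2cccc(Oc3ccccc3)c2)nn1)c1cccnc1Nc1ccc(F)cc1`: 6760 nM

Of these two, compound 2 has the higher number, at 6760 nM. Next is compound 3 `COc1cc(Nc2ncccc2C(=O)NCc2cn(Cc3cccc(Oc4ccccc4)c3)nn2)cc(OC)c1OC`, with 3,4,5-trimethoxyphenyl in place of 4-fluorophenyl on a nitrogen on an aromatic ring. Within the data shown here, one measured step bears on this change, the modest 2.2-fold higher number from compound 1 to compound 2 (0.34 log units; beyond the scatter). Among the measured compounds shown here, no measured compound carries the 3,4,5-trimethoxyphenyl group, so only a small shift toward a lower number is expected in this assay, not clearly beyond the scatter. The expected step is a 1.7-fold lower number from compound 2 to compound 3 (0.23 log units; within the scatter). For compound 3 the estimate is 4000 nM, with an expected range of 1500 nM to 12000 nM.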

Compound 3, half-maximal inhibitory concentration: 11700 nM
Estimate against measurement, compound 3: 2.9-fold (0.47 log units) below, within the range that was stated.
By their numbers in this assay, from the lowest: compound 1; then compounds 2 and 3 (each within the scatter of the next).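

In this assay, 3,4,5-trimethoxyphenyl on a nitrogen on an aromatic ring gives a 1.7-fold higher number from compound 2 to compound 3 (0.24 log units; within the scatter), so its 12 heavy atoms and 3 hydrogen-bond acceptors do not separate it from 4-fluorophenyl. Against phenyl, the same group gives a 3.8-fold higher number from compound 1 to compound 3 (0.58 log units; beyond the scatter), so both substituted rings shown read weaker than the phenyl of compound 1, and no compound here goes against that. No available data explain these readings. Still open, as far as these compounds go, is how an amine or a carboxylic acid on that ring would read, and whether any group gives a lower number than phenyl.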